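Working notes: hydroxy in place of amino

The source may hold more compounds than are shown below. What is called first, only, known or untested is meant among the compounds shown, and "the series" means these compounds.

Measured in an ADME assay on Vero cells (Chlorocebus sabaeus) for cytotoxicity, read by MTT assay; on this read-out higher numbers stand for lower toxicity in this test and lower numbers for higher toxicity in this test:
- compound 1 `Cn1nc(C(F)(F)F)cc1C(=O)Nc1ccc(S(=O)(=O)N2CCC(C(F)(F)F)CC2)cc1`: 159000 nM
- compound 2 `Cn1nc(C(F)(F)F)cc1C(=O)Nc1ccc(S(=O)(=O)N2CCC(N)CC2)cc1`: > 300000 nM (a limit of the assay, not a number)

Compound 2 stands at the limit of > 300000 nM in this assay, at which 1 of the 2 values shown sits, so its position is known only as a limit. The next compound, compound 3 `Cn1nc(C(F)(F)F)cc1C(=O)Nc1ccc(S(=O)(=O)N2CCC(O)CC2)cc1`, carries hydroxy in place of amino on a saturated ring carbon. Going by the values given here, only one measured step bears on this change: an at least 1.8-fold higher number from compound 1 to compound 2 (0.27 log units; that floor lies within the scatter), with amino in place of trifluoromethyl on a saturated ring carbon. That step has only a floor, and it does not involve hydroxy, so it is a weak guide to the size of the new step. No step beyond the scatter is therefore expected in this assay, and no direction can be expected with any confidence. The expected change is an at least 1.2-fold lower number from compound 2 to compound 3 (0.07 log units; that floor lies within the scatter). For compound 3 the expected value is 250000 nM, with an estimated range of 120000 nM to 300000 nM.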

Compound 3, half-maximal cytotoxic concentration: 274000 nM
Compound 3: middle estimate off by 1.1-fold (0.04 log units), on the low side, within the range that was stated.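

In this assay, going by these compounds alone, hydroxy in place of trifluoromethyl on the saturated ring carbon gives a 1.7-fold higher number from compound 1 to compound 3 (0.24 log units; within the scatter); this is the first step at this position read between two numbers rather than from a floor, and it does not separate the two groups. Hydroxy in place of amino gives an at least 1.0-fold lower number from compound 2 to compound 3 (0.03 log units; that floor lies within the scatter), which is a floor only and shows no step beyond the scatter at this ring carbon, so the 4-aminopiperidin-1-yl to 4-hydroxypiperidin-1-yl change has no measured size yet. Compound 2 carries a limit of the assay and not a number, so the true size of that step cannot be read: the limit of > 300000 nM in this assay, at which 1 of the 3 values shown sits.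

The compounds shown leave open whether a carboxylic acid, a methoxy group or a longer chain on this saturated ring carbon would give a step beyond the scatter in this assay. They also leave open whether a dimethylamino group would stay with the amino and hydroxy compounds, and whether any of these groups would read the same with another part of the shared core changed.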